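Dropping One Chloro Group From the Core of Compound 1

A few compounds are considered here, and "the series" means these few. Any claim that something is new, unique, unknown or untested is made for them only; others in the source may bear on it.

Compound 1 `ClCc1ccccc1Cn1cnc2nc(Cl)nc(Cl)c21` carries a chloromethyl-bearing benzyl group on a core that holds two chloro groups. In a functional assay on MDA-MB-435 cells (Homo sapiens) for cytotoxicity, read by sulforhodamine B assay, with a stated time of 48 h (a higher number here means that more compound is tolerated, a lower number that less compound is tolerated), compound 1 gives 58900 nM. A close relative of compound 1 is compound 2 `ClCc1ccc(Cn2cnc3c(Cl)nc(Cl)nc32)cc1`, and compound 2 gives 50100 nM in this assay. These two numbers lie within the usual scatter of each other, so compound 1 stands level with compound 2 rather than apart from it.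

Compound 3 `ClCc1ccccc1Cn1cnc2ncnc(Cl)c21` is compound 1 with a single change: hydrogen in place of chloro on an aromatic carbon. For the measured compounds named here, no measured pair here shows what such a change does, so the expectation rests on compound 1 alone. Because compound 1 gives 58900 nM, compound 3 is expected to land near that number. Compound 3 is estimated at 70000 nM, between 30000 nM and 160000 nM. The expected step of a 1.2-fold higher number from compound 1 to compound 3 (0.07 log units; within the scatter) is small, leaning if anything toward more compound being tolerated.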

Compound 3, concentration lethal to 50% of the cells: 7580 nM
Compound 3: middle estimate off by 9.2-fold (0.97 log units), on the high side; measured number outside the range, below it.
By their numbers in this assay, from the lowest: compound 3; then compounds 2 and 1 (each within the scatter of the next).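

In this assay, replacing the chloro group with hydrogen on the aromatic carbon between two ring nitrogen atoms gives a 7.8-fold lower number from compound 1 to compound 3 (0.89 log units; beyond the scatter), so less compound is tolerated after this change. For the compounds shown here, this single swap, with the rest of compound 1 left unchanged, shows that this position can move the number beyond the scatter, which the earlier compounds could not show because none of them differed from another at this carbon alone. Nothing measured here explains the drop.

Still open, going by these compounds, is whether another group on this carbon, such as an amine or a methoxy group, would also lower the number, or whether hydrogen is unusual here. On these data alone, the same swap on compound 2 is also open, so it remains unknown whether the step carries over to a compound with its chloromethyl-bearing benzyl group arranged differently.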